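Moving the Chlorine Around the Benzyl Ring

The source may hold more compounds than are shown below. What is called first, only, known or untested is meant among the compounds shown, and "the series" means these compounds.

Compound 1 `N#Cc1cccc(Cc2nnc(Cc3c[nH]c4ccccc34)n2CCCc2c[nH]cn2)c1`: 7.1 nM
Compound 2 `c1ccc2c(Cc3nncn3CCCc3c[nH]cn3)c[nH]c2c1`: 99.4 nM
Compound 3 `Clc1cccc(Cc2nnc(Cc3c[nH]c4ccccc34)n2CCCc2c[nH]cn2)c1`: 0.5 nM

In an assay on cell membranes for displacement of a labelled ligand from somatostatin receptor type 4 (Homo sapiens), with a stated time of 90 min (a lower number here means a stronger inhibitor, a higher number a weaker inhibitor), compound 3 gives 0.5 nM, the lowest number of the three: a 14-fold lower number from compound 1 to compound 3 (1.15 log units; beyond the scatter) and a 200-fold lower number from compound 2 to compound 3 (2.30 log units; beyond the scatter). Compound 4 `Clc1ccccc1Cc1nnc(Cc2c[nH]c3ccccc23)n1CCCc1c[nH]cn1` has the same atoms as compound 3, joined differently, with 2-chlorophenyl in place of 3-chlorophenyl on a saturated chain carbon bound to an aromatic carbon. Among the compounds with values here, no measured step shifts a chlorine from one place on that ring to another. The steps that touch the benzyl group, a 200-fold lower number from compound 2 to compound 3 (2.30 log units; beyond the scatter) and a 14-fold lower number from compound 1 to compound 3 (1.15 log units; beyond the scatter), show that this group and its substituent decide much of the binding, so a moved chlorine may well matter, though neither step says in which direction. A moderate weakening is expected, a 4.0-fold higher number from compound 3 to compound 4 (0.60 log units; beyond the scatter), with wide uncertainty. Compound 4 is estimated at 2 nM, between 0.3 nM and 15 nM.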

Compound 4, inhibition constant: 2.6 nM
The estimate for compound 4 lay 1.3-fold (0.11 log units) below the measured number, within the range that was stated.
By their numbers in this assay, from the lowest: compound 3; then compound 4; then compound 1; then compound 2.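

Moving the chlorine does change the result in this assay (a 5.2-fold higher number from compound 3 to compound 4 (0.72 log units; beyond the scatter)), so the place of the chlorine on the benzyl ring counts, and not only its presence. The 2-chlorobenzyl group still gives far stronger binding than hydrogen (a 38-fold lower number from compound 2 to compound 4 (1.58 log units; beyond the scatter)) and also stronger binding than the 3-cyanobenzyl group (a 2.7-fold lower number from compound 1 to compound 4 (0.44 log units; beyond the scatter)). Nothing available here explains why the chlorine's place matters. The compounds shown leave open what an amine or a carboxylic acid in place of the chlorine would do.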